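Amino at the pyridine ring position where methoxy cost potency

The compounds below may be only part of what the source reports. "The series", "measured", "known", "first", "only" and "open" are said of these compounds alone.

Measured compounds:
- compound 1, `COc1cccc(Cn2cnc3sc(-c4ccncc4)cc3c2=O)c1`: 6 nM
- compound 2, `COc1cccc(Cn2cnc3sc(-c4ccnc(OC)c4)cc3c2=O)c1`: 6920 nM

Among the compounds with values here, compound 1 stands at the lowest number of the two measured in an assay on isolated protein for inhibition of Rho-associated protein kinase 2 (Homo sapiens), read by radiometric assay and 33P incorporation, with a stated time of 40 min, in the presence of a further agent that is not named here (on this read-out lower numbers stand for stronger inhibition and higher numbers for weaker inhibition), with compound 2 as its only neighbour, and that neighbour lies far higher. Within the data shown here, the step between them, a 1200-fold higher number from compound 1 to compound 2 (3.06 log units; beyond the scatter), is the only measured change at this position, and it comes from putting methoxy in place of hydrogen on an aromatic carbon next to the ring nitrogen.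

Compound 3, `COc1cccc(Cn2cnc3sc(-c4ccnc(N)c4)cc3c2=O)c1`, has not yet been measured in this assay. It differs from compound 1 by amino in place of hydrogen on an aromatic carbon. The change sits at the same place as the methoxy of compound 2, but the entering amino group is smaller and brings a hydrogen-bond donor as well as an acceptor. Among the measured compounds shown here, the one relevant step, from compound 1 to compound 2, was very large and went toward weaker inhibition; a substituent at this place therefore seems costly. Since amino is not methoxy, the loss is expected to be smaller but still beyond the scatter. Compound 3 is estimated at 200 nM, in the range 20 nM to 2000 nM, which corresponds to an expected step of a 33-fold higher number from compound 1 to compound 3 (1.52 log units; beyond the scatter).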

Compound 3, half-maximal inhibitory concentration: 1 nM
Compound 3: the middle estimate sits 200-fold (2.30 log units) above what was measured; measured number outside the range, below it.
By their numbers in this assay, from the lowest: compound 3; then compound 1; then compound 2.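

In this assay, the place next to the ring nitrogen does not penalise every added group: amino in place of hydrogen gives a 6.0-fold lower number from compound 1 to compound 3 (0.78 log units; beyond the scatter), the opposite direction to methoxy in place of hydrogen, which gave a 1200-fold higher number from compound 1 to compound 2 (3.06 log units; beyond the scatter). The direct exchange of the two groups gives a 6900-fold lower number from compound 2 to compound 3 (3.84 log units; beyond the scatter), so the result here depends strongly on which group enters, not simply on whether the hydrogen is replaced. Nothing shown gives a measured reason for this split between amino and methoxy.

From the compounds shown here alone, with only hydrogen, amino and methoxy compared at this place, it remains open whether methylamino or dimethylamino would stay close to compound 3 or move toward compound 2, and where hydroxyl, methyl or fluorine would fall on the same scale. Going by these compounds, it is also open whether the gain from amino would persist if the methoxy group elsewhere in compound 3 were replaced by hydrogen, or if amino were placed elsewhere on the same six-membered ring.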